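Adding butyl to the chain of compound 2

The compounds below may be only part of what the source reports. "The series", "measured", "known", "first", "only" and "open" are said of these compounds alone.

Values so far in a functional assay on HL-60 cells (Homo sapiens) for activation; a higher number here means that more compound is needed for the effect, a lower number that less compound is needed:
compound 1 `CCCCCCCCCCCCCCNCC(N)CCCCN` gives 251 nM
compound 2 `CCCCCCCCCCCCNCC(N)CCCCN` gives 501 nM

Going by the values given here, compound 2 stands within the usual scatter of compound 1, the only other compound measured, so the two numbers cannot be ranked. Among the compounds with values here, one measured step bears on what follows: a 2.0-fold higher number from compound 1 to compound 2 (0.30 log units; within the scatter), where hydrogen replaces ethyl on a saturated chain carbon, and that step stays within the scatter.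

Compound 3 `CCCCCCCCCCCCCCCCNCC(N)CCCCN` goes the opposite way from that step. The difference is butyl in place of hydrogen on a saturated chain carbon, ten or more bonds along the chain from an amine nitrogen, with butyl in place of hydrogen on a saturated chain carbon, ten or more bonds along the chain from an amine nitrogen. The group entering is larger than the ethyl of compound 1, but a single step within the scatter is a weak guide, and nothing measured shows how far the direction holds. A modest move toward a lower number in this assay is therefore expected, at the edge of the scatter or only a little beyond it. The estimated size of this move is a 2.5-fold lower number from compound 2 to compound 3 (0.40 log units; beyond the scatter) in this expectation. For compound 3 the estimated value is 200 nM with an expected range from 70 nM to 560 nM in this assay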

Compound 3, half-maximal effective concentration: 251 nM
Beside the measured number, compound 3's estimate is 1.3-fold (0.10 log units) below it, and the stated range covers the measured number.
By their numbers in this assay, from the lowest: compounds 1, 3 and 2 (each within the scatter of the next).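

Butyl on a saturated chain carbon leaves the read-out in this assay within the scatter (a 2.0-fold lower number from compound 2 to compound 3 (0.30 log units; within the scatter)), so a group larger than the ethyl of the first step also produces no readable change at this place. Ethyl in place of hydrogen at the same place, now starting from the longer chain of compound 1, shows the same result (no change at the digits printed from compound 1 to compound 3 (within the scatter)), which means that all three compounds lie within the scatter of one another and cannot be ranked, with none of them going against that reading. No measurement at hand accounts for this flat response to chain length.

The compounds shown leave open whether a much shorter chain or a still longer one would move the number in this assay beyond the scatter. They also leave open whether a hydroxyl, a carboxylic acid or a phenyl ring at the end of the chain would be met as evenly as the added butyl and ethyl.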